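The source may hold more compounds than are shown below. What is called first, only, known or untested is meant among the compounds shown, and "the series" means these compounds.

Three compounds share one core and differ only in the group attached to a carbon with a double bond to nitrogen. Compound 1 `CS(=O)(=O)c1ccc(Cc2n[nH]c(=S)n2/N=C/c2ccccc2Cl)cc1` gives 42.7% in a functional assay on HeLa cells (Homo sapiens) for cytotoxicity, read by MTT assay, with a stated time of 48 h, tested at 50 uM; on this read-out lower numbers stand for a weaker effect and higher numbers for a stronger effect at the one concentration tested. Compound 2 `CS(=O)(=O)c1ccc(Cc2n[nH]c(=S)n2/N=C/c2ccc(Cl)cc2)cc1` gives 54%, and compound 3 `CS(=O)(=O)c1ccc(Cc2n[nH]c(=S)n2/N=C/c2ccccc2F)cc1` gives 21.9%, the lowest of the three: the move a number 20.8 percentage points lower from compound 1 to compound 3 (beyond the scatter) and the move a number 32.1 percentage points lower from compound 2 to compound 3 (beyond the scatter) both run downward, while a number 11.3 percentage points higher from compound 1 to compound 2 (beyond the scatter) is a modest rise. Compound 4 `CS(=O)(=O)c1ccc(Cc2n[nH]c(=S)n2/N=C/c2cccs2)cc1` carries thiophen-2-yl in place of 2-fluorophenyl on a carbon with a double bond to nitrogen. For the measured compounds named here, no measured step exchanges a six-membered aromatic ring of carbon only for a five-membered ring with a hetero atom, so the measured steps bear on this change only loosely; they show the read-out shifting by modest to large amounts whenever this group is altered. Compound 4 is therefore expected to give 35%, within 15% to 58%, an expected step of a number 13.1 percentage points higher from compound 3 to compound 4 (beyond the scatter).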

Compound 4, a percentage reported as activity, at one concentration (the size of the read-out at that concentration, not a potency): 48.6%
For compound 4 the middle estimate is 13.6 percentage points below the measured one; the measured number falls inside the stated range.
By their numbers in this assay, from the lowest: compound 3; then compounds 1, 4 and 2 (each within the scatter of the next, the first and the last beyond it).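

Compound 4 shows that this position accepts a five-membered aromatic ring with a hetero atom without the read-out in this assay falling to the level of compound 3, with a number 26.7 percentage points higher from compound 3 to compound 4 (beyond the scatter). Thiophen-2-yl instead sits level with both chlorophenyl groups, with a number 5.4 percentage points lower from compound 2 to compound 4 (within the scatter) and a number 5.9 percentage points higher from compound 1 to compound 4 (within the scatter), which leaves 2-fluorophenyl as the one group here with a clearly weaker read-out. The data offer no explanation for this difference. Still open, from the compounds shown here alone, is how an amine or a carboxylic acid on the aromatic ring would behave, and whether furan-2-yl would match thiophen-2-yl.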